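The source may report more compounds than this note shows. Statements on the series, on what has been measured and on what is new or still open speak of the compounds shown alone.

The shared core of compound 1 `N/C(=N\NC(=S)N1CCCC1)c1ccc(F)cn1` carries a thiosemicarbazide linked to a pyrrolidine and an amidine on the six-membered aromatic ring; in a functional assay on A-375 cells (Homo sapiens) for cytotoxicity, read by MTT assay, with a stated time of 72 h, tested at 30 uM (a lower number here means less inhibition of growth, a higher number more inhibition of growth at the concentration tested), compound 1 gives 83.2%. Compound 2 `Cc1cccc(/C(N)=N/NC(=S)N2CCCC2)n1` has a methyl group on that ring in place of the fluorine, and in this assay compound 2 gives 60.8%, the lower of the two numbers shown, with compound 1 standing higher by a gap beyond the usual scatter. Compound 3 `N/C(=N\NC(=S)N1CCCC1)c1ccccn1` removes the methyl: the change is hydrogen in place of methyl on an aromatic carbon, next to the ring nitrogen and meta to a large group. Going by the values given here, no directly comparable step between measured compounds exists. Since compound 1 without a methyl gives 83.2%, a modest rise is expected, so that the step from compound 2 to compound 3 is estimated at a number 9.2 percentage points higher from compound 2 to compound 3 (within the scatter). Compound 3 is expected to give 70%, within a range of 55% to 85%.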

Compound 3, percent growth inhibition at one concentration: 86%
The estimate for compound 3 lay 16 percentage points below the measured number, outside the stated range (above it).
By their numbers in this assay, from the lowest: compound 2; then compounds 1 and 3 (each within the scatter of the next).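

In this assay, hydrogen in place of methyl on an aromatic carbon, next to the ring nitrogen, gives a number 25.2 percentage points higher from compound 2 to compound 3 (beyond the scatter) and so shows that the lower number of compound 2 goes with this methyl at this place. Hydrogen in place of fluoro on an aromatic carbon gives a number 2.8 percentage points higher from compound 1 to compound 3 (within the scatter) and leaves compounds 1 and 3 indistinguishable here, so only the methyl step stands clear of the scatter among the two steps. The compounds shown offer no measurement that bears on the reason for the methyl step.

On these data alone, whether the drop belongs to methyl alone remains open, since an ethyl, a methoxy or an amine at the same place would be needed to tell. As far as these compounds go, how a methyl behaves elsewhere on this ring also remains open.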